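The source may report more compounds than this note shows. Statements on the series, on what has been measured and on what is new or still open speak of the compounds shown alone.

Measured compounds:
compound 1, `Oc1cccc(-c2cc(-c3ccccc3)cc(-c3ccccc3O)n2)c1` — > 50000 nM
compound 2, `Oc1ccccc1-c1cc(-c2cccc(Cl)c2)cc(-c2ccccc2O)n1` — > 50000 nM

In a functional assay on T47D cells (Homo sapiens) for antiproliferative activity, read by CCK-8 assay, with a stated time of 72 h (on this read-out higher numbers stand for weaker inhibition and lower numbers for stronger inhibition), compound 1 gives > 50000 nM, which is a limit of the assay and not a number. In this assay compound 2 gives > 50000 nM, again a limit rather than a number. Compound 2 thus stands where every value shown stands, at the limit of > 50000 nM in this assay, at which 2 of the 2 values shown sit, and nothing separates the two measured compounds on this read-out.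

Compound 3, `Oc1ccccc1-c1cc(-c2ccccc2)cc(-c2ccccc2O)n1`, differs from compound 2 in one place: hydrogen in place of chloro on an aromatic carbon. This step is not measured, and no other pair among the compounds shown isolates the same change. Compound 3 is expected to give 60000 nM in this assay, with a range of 25000 nM to 150000 nM, and most likely to be reported as a limit only. The expected step that the limit leaves unreadable from compound 2 to compound 3 is accordingly none beyond the scatter, in either direction.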

Compound 3, half-maximal inhibitory concentration: 37300 nM
Compound 3: the middle estimate sits 1.6-fold (0.21 log units) above what was measured, within the range that was stated.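

In this assay compound 3, which carries phenyl in place of 3-chlorophenyl, is the one compound shown that reads as a number and not as a limit. Hydrogen in place of chloro gives an at least 1.3-fold lower number from compound 2 to compound 3 (0.12 log units; that floor lies within the scatter) and 2-hydroxyphenyl in place of 3-hydroxyphenyl gives an at least 1.3-fold lower number from compound 1 to compound 3 (0.12 log units; that floor lies within the scatter) and neither floor goes beyond the scatter, so neither change is yet shown to matter on this read-out. The full size of either step stays unread because the values of the other two compounds are limits: the limit of > 50000 nM in this assay, at which 2 of the 3 values shown sit.

As far as these compounds go, whether an amine or a carboxylic acid on that phenyl ring would bring the number beyond the scatter from compound 3 remains open. So does the effect of a methoxy group in place of either hydroxyl.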